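This account rests on a few compounds, and the source may have more. Where it says the series, first, only, none or still open, it means among the compounds named here.

Of the compounds shown here, two have been measured in an assay on isolated protein for inhibition of thyroid hormone receptor beta (Homo sapiens), read by fluorescence, with a stated time of 30 min; a lower number here means a stronger inhibitor, a higher number a weaker inhibitor. Compound 1 `CCCN(CC1CCOC1)C(=O)c1cc(CC)c2oc(NCc3cccc(Cl)c3)nc2c1` gives 104 nM in this assay, and compound 2 `COc1cc(C(=O)N2CCCC2(C)C)cc2nc(NCc3cccc(Cl)c3)oc12` gives 47 nM; compound 2 thus holds the lower of the two numbers, and its gap to compound 1 lies beyond the usual scatter. Compound 3 `COc1cc(C(=O)N2CC[C@@H](O)[C@H](C)C2)cc2nc(NCc3cccc(Cl)c3)oc12` has not yet been measured. It departs from compound 2 by a single change: 4-hydroxy-3-methylpiperidin-1-yl in place of 2,2-dimethylpyrrolidin-1-yl on a carbonyl carbon. For the measured compounds named here, no measured pair traces this particular change, so the direction of the step rests on the two values alone. A step from compound 2 to compound 3 of modest size, leaning toward a somewhat higher number but possibly within the scatter, is expected, which is expressed as a 1.7-fold higher number from compound 2 to compound 3 (0.23 log units; within the scatter). For compound 3 in this assay, the estimated value is 80 nM, with a plausible range from 25 nM to 250 nM.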

Compound 3, half-maximal inhibitory concentration: 10 nM
Compound 3: middle estimate off by 8.0-fold (0.90 log units), on the high side; the measured number lies below the stated range.
By their numbers in this assay, from the lowest: compound 3; then compound 2; then compound 1.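

In this assay, 4-hydroxy-3-methylpiperidin-1-yl in place of 2,2-dimethylpyrrolidin-1-yl on a carbonyl carbon gives a 4.7-fold lower number from compound 2 to compound 3 (0.67 log units; beyond the scatter), the first step measured at this position. It shows that the number here responds to the group on this carbonyl carbon, and that a six-membered ring with a hydrogen-bond donor and two defined stereocentres is compatible with a lower number than the five-membered ring without one. Nothing available accounts for the size or direction of this step.

Ring size, the hydroxyl, the methyl and the stereochemistry all change in this one step, so their separate shares remain open. Also open, going by these compounds, is how a plain piperidin-1-yl, a 4-aminopiperidin-1-yl or the other stereoisomers of the 4-hydroxy-3-methylpiperidin-1-yl group would read in this assay on the same core.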